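Methyl for fluoro on the aryl ketone ester

The compounds below may be only part of what the source reports. "The series", "measured", "known", "first", "only" and "open" are said of these compounds alone.

Two esters on the shared core have so far been measured in a functional assay on MCF7 cells (Homo sapiens) for antiproliferative activity, read by MTT assay, with a stated time of 72 h, tested at 25 uM; on this read-out lower numbers stand for a stronger effect and higher numbers for a weaker effect at the one concentration tested. Compound 1 `CC(Cn1cnc2c1c(=O)n(C)c(=O)n2C)OC(=O)CC(=O)c1ccc(F)cc1` gives 88.5%, and compound 2 `CC(Cn1cnc2c1c(=O)n(C)c(=O)n2C)OC(=O)Sc1ccccc1` gives 86.8%. The numbers for compound 1 and compound 2 lie within the scatter of each other, so neither stands apart. Compound 3 `Cc1ccc(C(=O)CC(=O)OC(C)Cn2cnc3c2c(=O)n(C)c(=O)n3C)cc1` is not yet measured; it differs from compound 1 by methyl in place of fluoro on an aromatic carbon. Among the compounds with values here, no measured pair covers this change, so the step is expected to be small, none beyond the scatter, and in no settled direction. Compound 3 is therefore estimated at 87%, within a range from 75% to 98%, which means an expected step of a number 1.5 percentage points lower from compound 1 to compound 3 (within the scatter).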

Compound 3, a percentage reported as activity, at one concentration (the size of the read-out at that concentration, not a potency): 89%
Compound 3: the middle estimate sits 2 percentage points below what was measured; the range from low to high includes it.
By their numbers in this assay, from the lowest: compounds 2, 1 and 3 (each within the scatter of the next).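

Methyl in place of fluoro gives the first single-place comparison in the series, with a number 0.5 percentage points higher from compound 1 to compound 3 (within the scatter) in this assay. At the one concentration tested, this read-out therefore does not separate the 4-fluorophenyl and 4-methylphenyl ketone esters. No available data explain this result.

On these data alone, whether an amine, a carboxylic acid or a longer chain on the same aromatic carbon would give a step beyond the scatter remains open. So does whether a change elsewhere on the shared core would do so.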